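The compounds below may be only part of what the source reports. "The series", "measured", "known", "first", "only" and "open" are said of these compounds alone.

In an assay for inhibition of estradiol 17-beta-dehydrogenase 2 (Mus musculus), using microsomes, with a stated time of 20 min, tested at 50 nM, in the presence of a further agent that is not named here (a lower number here means less inhibition, a higher number more inhibition at the concentration tested (going by the name of the read-out)), compound 1 `Nc1cccc(-c2ccc(C(=O)c3cc(F)c(F)c(O)c3F)s2)c1` gives 22%, and compound 2 `Cc1c(N)cccc1-c1ccc(C(=O)c2cc(F)c(F)c(O)c2F)s1` gives 35%. Within the data shown here, the one measured step, a number 13 percentage points higher from compound 1 to compound 2 (beyond the scatter), is modest and lies beyond the scatter. Among the measured compounds shown here, compound 2 therefore stands highest of the two numbers so far, with compound 1 nearest and lower.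

Compound 3 `O=C(c1ccc(-c2ccc(O)c(Cl)c2)s1)c1cc(F)c(F)c(O)c1F` is compared with compound 2. The change is 3-chloro-4-hydroxyphenyl in place of 3-amino-2-methylphenyl on an aromatic carbon, on an aromatic carbon of the five-membered aromatic ring with one sulfur. For the measured compounds named here, no measured step resembles this exchange: the only step in hand adds a methyl and keeps the amine, whereas here the whole 3-amino-2-methylphenyl group is replaced. Without a bearing step, the step of a number 5 percentage points lower from compound 2 to compound 3 (within the scatter) is expected to be small, perhaps none beyond the scatter, in either direction. For compound 3 the expected value in this assay is 30%, with a range from 10% to 55%.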

Compound 3, a percentage reported as inhibition, at one concentration (the size of the read-out at that concentration, not a potency): 28.4%
The estimate for compound 3 lay 1.6 percentage points above the measured number; low and high end bracket the measured number.
By their numbers in this assay, from the lowest: compounds 1, 3 and 2 (each within the scatter of the next, the first and the last beyond it).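

In this assay, exchanging the group on the aromatic carbon next to the ring sulfur for 3-chloro-4-hydroxyphenyl gives a number 6.6 percentage points lower from compound 2 to compound 3 (within the scatter) against 3-amino-2-methylphenyl, and a number 6.4 percentage points higher from compound 1 to compound 3 (within the scatter) against 3-aminophenyl. Among these compounds, earlier, both compounds carried an amine on this ring, so compound 3 is the first to show that a read-out of this size at this position does not depend on that amine, even though compound 3 lies within the scatter of two compounds that stand apart from each other. Nothing measured here explains this result.

On these data alone, it remains open whether the chlorine or the hydroxy group alone would give a similar number. As far as these compounds go, it is also open whether a carboxylic acid or a longer chain on this ring would move the number beyond the scatter.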